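Methoxy to propoxy: compound 3 to compound 4

The source may report more compounds than this note shows. Statements on the series, on what has been measured and on what is new or still open speak of the compounds shown alone.

In a functional assay on the whole organism (strain Sprague-Dawley) for inhibition, with Rattus norvegicus as the target, with a stated time of 10 min (a lower number here means that less compound is needed, a higher number that more compound is needed for the effect), compound 1 (`O=C(O)c1cnc(-c2ccccc2Cl)[nH]c1=O`) gives 5 mg/kg. Compound 2 (`O=C(O)c1cnc(-c2ccccc2O)[nH]c1=O`) gives > 5 mg/kg, which is a limit and not a number. Compound 3 (`COc1ccccc1-c1ncc(C(=O)O)c(=O)[nH]1`) gives 10 mg/kg. It stands within the scatter of compound 1, the step being a 2.0-fold higher number from compound 1 to compound 3 (0.30 log units; within the scatter).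

Compound 4 (`CCCOc1ccccc1-c1ncc(C(=O)O)c(=O)[nH]1`) turns the methoxy of compound 3 into propoxy: ethyl in place of hydrogen on a saturated chain carbon bound to an oxygen on an aromatic ring. For the measured compounds named here, no measured step lengthens this chain. Going by the values given here, the one measured change on that oxygen is a step that the limit leaves unreadable from compound 2 to compound 3, which gives no size to carry over. Among the compounds with values here, the only readable step is the one from chloro to methoxy, so the expected change in this assay stays small, and the expected step is a 1.7-fold lower number from compound 3 to compound 4 (0.22 log units; within the scatter), not beyond the scatter. For compound 4 the estimate is 6 mg/kg, with an expected range of 1.5 mg/kg to 20 mg/kg.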

Compound 4, dose for 50% inhibition: 0.9 mg/kg
For compound 4 the middle estimate is 6.7-fold (0.82 log units) above the measured one; the whole stated range lies above it.
By their numbers in this assay, from the lowest: compound 4; then compounds 1 and 3 (each within the scatter of the next).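

In this assay, for the compounds shown here, methoxy to propoxy on the aromatic ring gives an 11-fold lower number from compound 3 to compound 4 (1.05 log units; beyond the scatter), whereas the only earlier readable step stayed within the scatter, so this oxygen substituent can move the dose strongly. Propoxy also stands clear of chloro, with a 5.6-fold lower number from compound 1 to compound 4 (0.74 log units; beyond the scatter), and of hydroxy, with an at least 5.5-fold lower number from compound 2 to compound 4 (0.74 log units; beyond the scatter). That hydroxy comparison rests on a limit and not a number: the limit of > 5 mg/kg in this assay, at which 1 of the 4 values shown sits.

From the compounds shown here alone, with only methoxy and propoxy as alkoxy groups, the shape of the chain-length trend stays open. Ethoxy, butoxy, or a propoxy chain ending in an amine would test how far it runs.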